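From 3-methylbenzyl to 4-methylbenzyl: an expected step

The compounds below may be only part of what the source reports. "The series", "measured", "known", "first", "only" and "open" are said of these compounds alone.

Measured in a functional assay on HL-60 cells (Homo sapiens) for antiproliferative activity, with a stated time of 72 h; on this read-out higher numbers stand for weaker inhibition and lower numbers for stronger inhibition:
Compound 1 `OC[C@H]1O[C@@H](n2cnc3c(NCc4ccc(Cl)cc4)ncnc32)[C@H](O)[C@@H]1O`: 1700 nM
Compound 2 `Cc1cccc(CNc2ncnc3c2ncn3[C@@H]2O[C@H](CO)[C@@H](O)[C@H]2O)c1`: 6400 nM

Of the two measured compounds, compound 2 stands highest at 6400 nM and is thus the weaker inhibitor. Compound 3 `Cc1ccc(CNc2ncnc3c2ncn3[C@@H]2O[C@H](CO)[C@@H](O)[C@H]2O)cc1` has not yet been measured. The change from compound 2 is 4-methylphenyl in place of 3-methylphenyl on a saturated chain carbon bound to a nitrogen on an aromatic ring. Among the measured compounds shown here, only one measured step bears on this, the modest 3.8-fold higher number from compound 1 to compound 2 (0.58 log units; beyond the scatter), and it exchanged 4-chlorophenyl for 3-methylphenyl. For the measured compounds named here, no measured step changes the methyl position alone, so this evidence is indirect. Compound 1, at 1700 nM, shares the 4-substituted naming with compound 3, so a small move towards a lower number is expected in this assay, probably within the scatter. The estimated step is a 1.8-fold lower number from compound 2 to compound 3 (0.26 log units; within the scatter). Compound 3 is expected at 3500 nM, with an estimated range of 1400 nM to 8500 nM.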

Compound 3, half-maximal inhibitory concentration: > 166000 nM
Compound 3 gave a limit, no number; the forecaster's own chance of this, stated with the estimate: 2%; at least 47-fold (1.67 log units) between middle value and limit.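

In this assay compound 3 gave a limit and no number: the limit of > 166000 nM in this assay, at which 1 of the 3 values shown sits. The swap of 3-methylphenyl for 4-methylphenyl on the saturated chain carbon keeps the same atoms joined differently, yet it gives an at least 25-fold higher number from compound 2 to compound 3 (1.41 log units; beyond the scatter), so this place responds sharply to where the methyl sits, a sensitivity the modest 3.8-fold higher number from compound 1 to compound 2 (0.58 log units; beyond the scatter) did not reveal. Methyl in place of chloro on an aromatic carbon gives an at least 97-fold higher number from compound 1 to compound 3 (1.98 log units; beyond the scatter), which shows that a 4-substituted phenyl does not by itself keep a measurable value in this assay, since the outcome depends on which group is present.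

From the compounds shown here alone, the true size of both new steps stays unknown, as compound 3 gave only a limit. Going by these compounds, whether 4-fluorophenyl or 4-methoxyphenyl would follow compound 1 or compound 3, and what unsubstituted phenyl would give, also remains open.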